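The source may hold more compounds than are shown below. What is called first, only, known or untested is meant among the compounds shown, and "the series" means these compounds.

Compound 1 `CCCCCCC#Cc1c(CCCCCC)oc2nc(=O)n(Cc3cn(Cc4ccccc4)nn3)cc12` gives 25800 nM in a functional assay on HepG2 cells (Homo sapiens) for antiproliferative activity, read by MTT assay, with a stated time of 72 h; a lower number here means a stronger inhibitor, a higher number a weaker inhibitor. Compound 2 `O=c1nc2oc(CCCCl)c(C#CCCCCCl)c2cn1Cc1cn(-c2ccc(F)cc2)nn1` gives 36900 nM. Compound 3 `O=c1nc2oc(CCCCl)c(C#CCCCCl)c2cn1Cc1cn(-c2ccc(Cl)cc2)nn1` gives 72500 nM.

All three numbers are weak and lie within the usual scatter of one another, so compound 2 is not separated from compound 1 or from compound 3 by more than repeat measurements would show. The unmeasured compound 4 `O=c1nc2oc(CCCCl)cc2cn1Cc1cn(-c2ccc(F)cc2)nn1` differs from compound 2 in one place: hydrogen in place of 6-chlorohex-1-yn-1-yl on an aromatic carbon. For the measured compounds named here, no step between measured compounds informs this change, so the expectation rests on the weak numbers of compounds 1, 2 and 3 alone. A modest loss is expected, the step from compound 2 to compound 4 being estimated at a 1.9-fold higher number from compound 2 to compound 4 (0.28 log units; within the scatter). Compound 4 is therefore estimated at 70000 nM, in a range from 25000 nM to 200000 nM.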

Compound 4, half-maximal inhibitory concentration: 14600 nM
For compound 4 the middle estimate is 4.8-fold (0.68 log units) above the measured one; the whole stated range lies above it.
By their numbers in this assay, from the lowest: compounds 4, 1, 2 and 3 (each within the scatter of the next, the first and the last beyond it).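

In this assay, hydrogen in place of 6-chlorohex-1-yn-1-yl on this aromatic carbon gives a 2.5-fold lower number from compound 2 to compound 4 (0.40 log units; beyond the scatter) and so shows that the chain is not needed here for the weak activity seen. The earlier compounds shown here all carried a chain with a triple bond at this carbon, so they could not show this. Nothing measured here explains the step. On these data alone, whether a methyl group, an amine or a carboxylic acid on this carbon would match hydrogen remains open. So does whether the same change would give a similar step with the other substituents of compound 1 or compound 3.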